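The source may hold more compounds than are shown below. What is called first, only, known or untested is meant among the compounds shown, and "the series" means these compounds.

Going by the values given here, in a functional assay on SK-OV-3 cells (Homo sapiens) for cytotoxicity, read by spectrophotometry, with a stated time of 72 h (on this read-out lower numbers stand for stronger inhibition and higher numbers for weaker inhibition), compound 1 (`COc1cc(-n2c(-c3ccc([N+](=O)[O-])cc3)cccc2=O)cc(OC)c1OC`) gives 201 nM and stands lowest of the two numbers so far, while compound 2 (`COc1cc(-n2c(-c3ccc(OC(F)(F)F)cc3)cccc2=O)cc(OC)c1OC`) gives 461 nM as the only other number. Compound 3 (`COc1cc(-n2c(-c3cccc(O)c3)cccc2=O)cc(OC)c1OC`) is not yet measured. Its change from compound 1 puts 3-hydroxyphenyl in place of 4-nitrophenyl on an aromatic carbon next to the ring nitrogen (3-hydroxyphenyl in place of 4-nitrophenyl on an aromatic carbon). Among the compounds with values here, the one measured step that bears on this also removes the nitro group and is modest (a 2.3-fold higher number from compound 1 to compound 2 (0.36 log units; beyond the scatter)). Within the data shown here, no measured compound carries 3-hydroxyphenyl, so a similarly modest move to a higher number is expected, with wide uncertainty (a 2.2-fold higher number from compound 1 to compound 3 (0.35 log units; beyond the scatter)). For compound 3 the estimated value is 450 nM (range 120 nM to 1700 nM).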

Compound 3, half-maximal inhibitory concentration: 1460 nM
Compound 3: the middle estimate sits 3.2-fold (0.51 log units) below what was measured; measured number inside the range.
By their numbers in this assay, from the lowest: compound 1; then compound 2; then compound 3.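

In this assay, the group on this carbon can shift the number further than compound 2 suggested: 3-hydroxyphenyl in place of 4-nitrophenyl gives a 7.3-fold higher number from compound 1 to compound 3 (0.86 log units; beyond the scatter). This change replaces the nitro group with a hydroxyl and also moves the substituent to a different place on the phenyl ring, so the two changes cannot be told apart. Nothing available explains the rise.

The compounds shown leave open how 4-hydroxyphenyl would compare with 3-hydroxyphenyl. They also leave open how 3-aminophenyl, which carries an amine, would compare.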